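A few compounds are considered here, and "the series" means these few. Any claim that something is new, unique, unknown or untested is made for them only; others in the source may bear on it.

Compound 2 `CC(C)C(c1ccc(-c2ccc3cccc(F)c3c2)[nH]c1=O)N1CCN/C1=N\C#N` carries the group that is exchanged in this account. In an ADME assay on microsomes from liver (Mus musculus) for metabolic stability (a higher number here means that the compound lasts longer, a lower number that the compound disappears faster), compound 2 gives 0.207 h. Among the two numbers measured, compound 2 holds the lowest one, and the nearest to it is compound 3 `CC(C)C(c1nnc[nH]1)c1ccc(-c2ccc3cccc(F)c3c2)[nH]c1=O`, which in this assay gives 0.213 h, a gap within the scatter. The third compound, compound 1 `CCn1ncc2c(F)cc(-c3ccc(C(CC)(CC)c4nnc(C)[nH]4)c(=O)[nH]3)cc21`, gives in this assay only a limit of the assay, > 3 h.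

The change to compound 4 `Cc1c[nH]c(C(c2ccc(-c3ccc4cccc(F)c4c3)[nH]c2=O)C(C)C)n1` is a group of 6 heavy atoms (4 carbon, 2 nitrogen; one five-membered aromatic ring with 2 hetero atoms) in place of a group of 8 heavy atoms (4 carbon, 4 nitrogen; one five-membered non-aromatic ring with 2 hetero atoms), on a saturated chain carbon bound to an aromatic carbon and a saturated chain carbon. Within the data shown here, one measured step bears on it: a 1.0-fold higher number from compound 2 to compound 3 (0.01 log units; within the scatter), in which the same group of 8 heavy atoms leaves the same place and a five-membered aromatic ring with 3 hetero atoms enters. Compound 4 instead receives a five-membered aromatic ring with 2 hetero atoms at that place, a closely related exchange, so the step to compound 4 in this assay is expected to be a 1.1-fold higher number from compound 2 to compound 4 (0.03 log units; within the scatter), no movement beyond the scatter in either direction. Compound 4 is therefore estimated at 0.22 h in this assay, with a range from 0.1 h to 0.5 h.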

Compound 4, half-life: < 0.0667 h
Compound 4: only a limit was reported; the forecaster's own chance of this, stated with the estimate: 5%; middle value at least 3.2-fold (0.51 log units) from the limit.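

At this saturated chain carbon, the exchange of the group was not neutral in every case in this assay: the five-membered aromatic ring with 3 hetero atoms had given a 1.0-fold higher number from compound 2 to compound 3 (0.01 log units; within the scatter), whereas 4-methyl-1H-imidazol-2-yl gives an at least 3.1-fold lower number from compound 2 to compound 4 (0.49 log units; beyond the scatter). The direct comparison of the two aromatic rings, with 4-methyl-1H-imidazol-2-yl in place of 4H-1,2,4-triazol-3-yl, gives an at least 3.1-fold lower number from compound 3 to compound 4 (0.50 log units; beyond the scatter), so the outcome at this place depends on which five-membered aromatic ring enters, not merely on the loss of the group of compound 2. The full size of both steps cannot be read because compound 4 stands at a limit of the assay: the limit of < 0.0667 h in this assay, at which 1 of the 4 values shown sits.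

Left open is whether the methyl group or the ring itself accounts for the step from the triazole to the imidazole, as the two change together here, and a plain 1H-imidazol-2-yl at this place would separate them. Compound 1, which gives a limit of > 3 h, differs from the others in more than one place and does not settle this question.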